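The source may hold more compounds than are shown below. What is called first, only, known or untested is meant among the compounds shown, and "the series" means these compounds.

Measured compounds:
compound 1 `O=C(Nc1cccc(-n2cc(-c3ccncc3)c(-c3cc(O)cc(Cl)c3)n2)c1)Nc1ccc(Cl)c(C(F)(F)F)c1`: -58%
compound 2 `O=C(Nc1cccc(-n2cc(-c3ccncc3)c(-c3cc(O)cc(Cl)c3)n2)c1)Nc1ccc(Cl)c(Cl)c1`: -36%

In a functional assay on SW-620 cells (Homo sapiens) for inhibition, read by sulforhodamine B assay, with a stated time of 48 h, tested at 100 uM (on this read-out lower numbers stand for a stronger effect and higher numbers for a weaker effect at the one concentration tested), compound 1 gives -58%, the lowest of the two numbers, and compound 2 gives -36%. Among the measured compounds shown here, the single step between them, a number 22 percentage points higher from compound 1 to compound 2 (beyond the scatter), concerns chloro in place of trifluoromethyl on an aromatic carbon and leaves the rest of the shared core untouched.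

Compound 3 `COc1cc(Cl)cc(-c2nn(-c3cccc(NC(=O)Nc4ccc(Cl)c(C(F)(F)F)c4)c3)cc2-c2ccncc2)c1` is not yet measured in this assay. It differs from compound 1 by methyl in place of hydrogen on an oxygen on an aromatic ring. For the measured compounds named here, no measured step touches the hydroxy group; the only measured step sits elsewhere in the molecule and says nothing about a change of hydroxy to methoxy. With nothing to go on, no step beyond the scatter is expected, and the number for compound 3 is expected close to that of compound 1, with a wide range. The expected step is a number 6 percentage points higher from compound 1 to compound 3 (within the scatter). The estimate for compound 3 is -52%, ranging from -85% to -15%.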

Compound 3, a percentage reported as activity, at one concentration (the size of the read-out at that concentration, not a potency): -58%
The estimate for compound 3 lay 6 percentage points above the measured number; the range from low to high includes it.
By their numbers in this assay, from the lowest: compounds 1 and 3 (each within the scatter of the next); then compound 2.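

In this assay, methyl in place of hydrogen on the oxygen, turning 3-chloro-5-hydroxyphenyl into 3-chloro-5-methoxyphenyl, gives no change at the digits printed from compound 1 to compound 3 (within the scatter). Among the compounds shown here, this is the first reading at this position, and it shows that, with the rest of compound 1 unchanged, the hydrogen on this oxygen is not needed to keep the read-out at the one concentration tested, unlike the change elsewhere in the molecule that gave a number 22 percentage points higher from compound 1 to compound 2 (beyond the scatter). Nothing available explains why the read-out holds across this change.

Going by these compounds, whether the position also accepts a longer chain on the oxygen, such as ethoxy or benzyloxy, or an amine or a carboxylic acid in place of the hydroxy, remains open. Also open, on these data alone, is whether methoxy gives the same result with the rest of compound 2.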